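This account rests on a few compounds, and the source may have more. Where it says the series, first, only, none or still open, it means among the compounds named here.

Measured compounds:
compound 1 `CCCCCCCCS(=O)(=O)Nc1cc(-c2ccccc2Cl)ccc1C(=O)O` — 26900 nM
compound 2 `CCCCCCCCS(=O)(=O)Nc1ccc(-c2ccccc2-c2ccccc2)cc1C(=O)O` — 10100 nM

Both compounds were tested in an assay on mitochondria (strain BALB/c) for inhibition of glycerol-3-phosphate acyltransferase 1, mitochondrial (Mus musculus), read by scintillation counting, with a stated time of 10 min; on this read-out higher numbers stand for weaker inhibition and lower numbers for stronger inhibition. Compound 1 gives the higher of the two numbers, at 26900 nM, and so stands as the weaker inhibitor of the pair. Compound 2, whose value in this assay is 10100 nM, gives a lower number, and the gap between the two lies beyond the usual scatter of this assay. Going by the values given here, no further measured pair shares a single point of difference, so no step between measured compounds can be read off.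

Compound 3 `CCCCCCCCS(=O)(=O)Nc1cc(CCc2ccc(OC)cc2)ccc1C(=O)O` has not yet been measured in this assay. It differs from compound 1 in one place: 2-(4-methoxyphenyl)ethyl in place of 2-chlorophenyl on an aromatic carbon. Among the compounds with values here, nothing among the measured compounds isolates this change, so the direction of the step is open. The two values that exist suggest a compound of this series may land anywhere in a broad band around compound 1. Compound 3 is therefore expected at 15000 nM, within a range of 4000 nM to 60000 nM, which would be a step of a 1.8-fold lower number from compound 1 to compound 3 (0.25 log units; within the scatter), and no step beyond the scatter is confidently expected.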

Compound 3, half-maximal inhibitory concentration: 43000 nM
The estimate for compound 3 lay 2.9-fold (0.46 log units) below the measured number; low and high end bracket the measured number.
By their numbers in this assay, from the lowest: compound 2; then compounds 1 and 3 (each within the scatter of the next).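

In this assay, 2-(4-methoxyphenyl)ethyl in place of 2-chlorophenyl gives a 1.6-fold higher number from compound 1 to compound 3 (0.20 log units; within the scatter), so the two groups cannot be told apart at this aromatic carbon, para to a carboxy group. Going by these compounds alone, this is the first reading at this position of a substituent other than 2-chlorophenyl, and it shows that the entering group, with 10 heavy atoms and 1 hydrogen-bond acceptor against 7 heavy atoms and 0 hydrogen-bond acceptors, leaves the number within the scatter of the number for compound 1. No measured evidence is available to account for this outcome.

Because the entering group differs from 2-chlorophenyl in both its two-carbon link and its ring substituents, the compounds shown cannot separate what each of these contributes, and a directly attached 4-methoxyphenyl, a plain 2-phenylethyl or a 2-(4-hydroxyphenyl)ethyl at this position would be needed to do so. Going by these compounds, it also remains open whether a more polar end group on the same chain, such as an amine or a carboxylic acid on the outer ring, would move the number beyond the scatter.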